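Cyclopropyl for isopropyl on the ring amide nitrogen

A few compounds are considered here, and "the series" means these few. Any claim that something is new, unique, unknown or untested is made for them only; others in the source may bear on it.

Measured compounds:
compound 1 `CN1C(=O)CN(Cc2ccc(-c3cccc(CN4CCCCC4)n3)cc2)C1=O` with 1.83 h
compound 2 `CC(C)N1C(=O)CN(Cc2ccc(-c3cccc(CN4CCCCC4)n3)cc2)C1=O` with 1.35 h

Both compounds were tested in an in vitro ADME assay on microsomes from liver (Homo sapiens) for metabolic stability, read by LC-MS, using NADPH, tested at 1 uM (a lower number here means that the compound disappears faster, a higher number that the compound lasts longer), and share one core, differing only in the group on an amide-type nitrogen in a ring. Among the measured compounds shown here, the single measured step, a 1.4-fold lower number from compound 1 to compound 2 (0.13 log units; within the scatter), shows that replacing methyl with isopropyl at that position gives a number within the scatter. Compound 2 therefore stands at the lowest of the two numbers, but its gap to compound 1 is not beyond the scatter, so no ordering between the two can be read.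

Compound 3 `O=C1CN(Cc2ccc(-c3cccc(CN4CCCCC4)n3)cc2)C(=O)N1C1CC1` has not yet been measured in this assay. Its change from compound 2 is cyclopropyl in place of isopropyl on an amide-type nitrogen in a ring. For the measured compounds named here, the only step that bears on this place is a 1.4-fold lower number from compound 1 to compound 2 (0.13 log units; within the scatter), and that step was within the scatter. Since the swap from isopropyl to cyclopropyl keeps the same number of heavy atoms at the same position, compound 3 is expected to give a half-life close to that of compound 2, with no step beyond the scatter, which is the expectation a 1.1-fold higher number from compound 2 to compound 3 (0.05 log units; within the scatter). The estimated value for compound 3 is 1.5 h, within the expected range 0.8 h to 2.8 h.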

Compound 3, half-life in the Homo sapiens assay: 2 h
Estimate against measurement, compound 3: 1.3-fold (0.12 log units) below, and the stated range covers the measured number.
By their numbers in the Homo sapiens assay, from the lowest: compounds 2, 1 and 3 (each within the scatter of the next).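

In the Homo sapiens assay, cyclopropyl brings one three-membered non-aromatic ring of carbon only to the amide-type nitrogen in a ring, with the same 3 heavy atoms as isopropyl, and gives a 1.5-fold higher number from compound 2 to compound 3 (0.17 log units; within the scatter) and a 1.1-fold higher number from compound 1 to compound 3 (0.04 log units; within the scatter), so no ordering among the methyl, isopropyl and cyclopropyl compounds can be read at this place. In a physicochemical assay for acid dissociation, compound 2 is recorded as "not determined" (no result reported) and compound 3 gives 9, so this read-out offers no comparison between the two. Nothing available offers an explanation for the numbers at this position.

The compounds shown leave open whether a longer chain such as n-butyl, or a group carrying an amine or a carboxylic acid, on the amide-type nitrogen in a ring would give a half-life beyond the scatter of these three in the Homo sapiens assay. With a single number in the physicochemical assay, they also leave open how that read-out responds to the group at this place.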